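A few compounds are considered here, and "the series" means these few. Any claim that something is new, unique, unknown or untested is made for them only; others in the source may bear on it.

Compound 1 `COc1cc(C(=O)c2sc(-c3ccc(C)cc3)cc2N)cc(OC)c1OC` gives 16 nM in a functional assay on FM3A cells (Mus musculus) for antiproliferative activity; on this read-out lower numbers stand for stronger inhibition and higher numbers for weaker inhibition.
Compound 2 `COc1cc(C(=O)c2sc(-c3ccsc3)cc2N)cc(OC)c1OC` gives 3.7 nM in this assay.
Compound 3 `COc1cc(C(=O)c2sc(-c3ccc([N+](=O)[O-])cc3)cc2N)cc(OC)c1OC` gives 64 nM in this assay.

Among these three, compound 3 stands with the highest number, meaning the weakest inhibition of cell growth. The nearest measured neighbour is compound 1, reached by a 4.0-fold higher number from compound 1 to compound 3 (0.60 log units; beyond the scatter); the furthest is compound 2, reached by a 17-fold higher number from compound 2 to compound 3 (1.24 log units; beyond the scatter).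

Compound 4 `COc1cc(C(=O)c2sc(-c3ccccc3)cc2N)cc(OC)c1OC` differs from compound 3 in one place: hydrogen in place of nitro on an aromatic carbon. Seen one bond further out, the change reads 4-nitrophenyl to phenyl.

Within the data shown here, one measured step bears on this. Going from compound 1 to compound 3, nitro in place of methyl on the aromatic carbon gave a 4.0-fold higher number from compound 1 to compound 3 (0.60 log units; beyond the scatter), a modest loss of potency. Compound 4 takes the nitro away again, leaving only hydrogen on that carbon. Among the measured compounds shown here, there is no measured pair showing hydrogen against methyl on this ring, so the best anchor is compound 1 with 16 nM. The number for compound 4 is therefore expected to fall back close to that of compound 1, which means a modest step downward, a 3.6-fold lower number from compound 3 to compound 4 (0.55 log units; beyond the scatter), in this assay.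

For compound 4 the estimate is 18 nM, with a likely range of 6 nM to 55 nM.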

Compound 4, half-maximal inhibitory concentration: 13 nM
Compound 4: middle estimate off by 1.4-fold (0.14 log units), on the high side; the range from low to high includes it.
By their numbers in this assay, from the lowest: compound 2; then compounds 4 and 1 (each within the scatter of the next); then compound 3.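

Removing the nitro group gave a 4.9-fold lower number from compound 3 to compound 4 (0.69 log units; beyond the scatter) in this assay, so on this six-membered ring the loss of potency goes with the nitro group itself. Hydrogen and methyl on that carbon cannot be told apart, with a 1.2-fold lower number from compound 1 to compound 4 (0.09 log units; within the scatter), which suggests that this position tolerates either of these two small substituents, while nitro stands out as the one that costs potency among the three seen here. The bare phenyl ring still trails the thiophen-3-yl ring of compound 2, with a 3.5-fold higher number from compound 2 to compound 4 (0.55 log units; beyond the scatter). The better number of compound 2 therefore goes with the change of ring and not only with the missing methyl group.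

The data shown offer no independent measurement that explains why any of these changes moves the number as it does. Going by these compounds, it remains open whether an amine or a chlorine atom on that same carbon would behave like hydrogen and methyl or like nitro, and whether the thiophen-3-yl ring would keep its lead if it carried a methyl group of its own.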